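The source may hold more compounds than are shown below. What is called first, only, known or untested is meant among the compounds shown, and "the series" means these compounds.

For the measured compounds named here, in a functional assay on SK-MEL cells (Homo sapiens) for cytotoxicity, read by MTT assay, with a stated time of 6 days (on this read-out higher numbers stand for an effect only at larger amounts of compound and lower numbers for an effect already at smaller amounts), compound 2 `COC(=O)c1c(-c2ccc([N+](=O)[O-])cc2)oc2cc(OC)ccc2c1=O` gives 2.84 ug/mL, the lowest actual number so far. Compound 3 `COC(=O)c1c(-c2ccc(O)cc2)oc2cc(OC)ccc2c1=O` gives 19.6 ug/mL. Compound 1 `COC(=O)c1c(-c2ccc([N+](=O)[O-])cc2)oc2ccccc2c1=O` gives > 25 ug/mL, which is a limit of this assay and not a number.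

Two measured steps involve compound 2. Methoxy in place of hydrogen on an aromatic carbon gave an at least 8.8-fold lower number from compound 1 to compound 2 (0.94 log units; beyond the scatter), and hydroxy in place of nitro on an aromatic carbon gave a 6.9-fold higher number from compound 2 to compound 3 (0.84 log units; beyond the scatter).

Compound 4 `COc1ccc2c(=O)c(C(=O)O)c(-c3ccc([N+](=O)[O-])cc3)oc2c1` differs from compound 2 at another place: hydrogen in place of methyl on an oxygen next to a carbonyl group. This is hydrogen in place of methyl on an oxygen next to a carbonyl group, so methoxycarbonyl becomes carboxy. Neither measured step changes this group, so they offer only a rough guide to size and direction. Both show that a single change can shift the number clearly, and each of the other compounds sits higher than compound 2. A higher number is therefore expected, of a modest size like the step to compound 3. The expected step is a 3.5-fold higher number from compound 2 to compound 4 (0.55 log units; beyond the scatter). For compound 4 the estimated value is 10 ug/mL, with an expected range from 3.5 ug/mL to 30 ug/mL.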

Compound 4, concentration for half-maximal effect: > 25 ug/mL
Compound 4: a limit, no number (the forecaster's own chance of this, stated with the estimate: 25%); at least 2.5-fold (0.39 log units) between middle value and limit.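

Until now the methoxycarbonyl group was the same in every compound, so nothing showed whether this position matters. In this assay, changing methoxycarbonyl to carboxy gives an at least 8.8-fold higher number from compound 2 to compound 4 (0.94 log units; beyond the scatter), so a change at this position alone is enough to lose the low number of compound 2. Compound 4 gives > 25 ug/mL, which is a limit and not a number, so the step has a lower end but no known upper end: the limit of > 25 ug/mL in this assay, at which 2 of the 4 values shown sit.

The compounds shown leave open how other groups at this position would read, such as an ethyl ester, a primary amide or a nitrile, and whether any of them would stay close to compound 2. From the compounds shown here alone, it also remains open whether the same change would have a similar outcome with hydroxy in place of nitro, as in compound 3.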